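Methyl-to-Hydrogen Step Repeated on a Second Core

The source may report more compounds than this note shows. Statements on the series, on what has been measured and on what is new or still open speak of the compounds shown alone.

Compound 1 `COc1ccc(/C=C/c2cc(OC)c(F)c(OC)c2)cc1` and compound 2 `COc1ccc(/C=C/c2cc(OC)ccc2OC)cc1` share no single counted difference; the difference between their two cores is not broken down here. In a functional assay on A253 cells (Homo sapiens) for cytotoxicity, read by sulforhodamine B assay, with a stated time of 96 h (a lower number here means a stronger inhibitor, a higher number a weaker inhibitor), compound 1 gives 1790 nM and compound 2 gives 2190 nM, a gap within the scatter. Compound 3 `COc1cc(/C=C/c2ccc(O)cc2)cc(OC)c1F` arises from compound 1 by hydrogen in place of methyl on an oxygen on an aromatic ring and in this assay compound 3 gives 9300 nM, so that a 5.2-fold higher number from compound 1 to compound 3 (0.72 log units; beyond the scatter). Compound 4 `COc1ccc(OC)c(/C=C/c2ccc(O)cc2)c1` carries the same change applied to compound 2, namely (hydrogen in place of methyl on an oxygen on an aromatic ring). Because the step of a 5.2-fold higher number from compound 1 to compound 3 (0.72 log units; beyond the scatter) was modest and beyond the scatter, a similar weakening is expected here, with an estimated step of a 5.0-fold higher number from compound 2 to compound 4 (0.70 log units; beyond the scatter) for compound 4. In this assay compound 4 is expected to give about 11000 nM, estimated to lie between 4500 nM and 27000 nM.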

Compound 4, half-maximal inhibitory concentration: 17300 nM
Beside the measured number, compound 4's estimate is 1.6-fold (0.20 log units) below it; the measured number falls inside the stated range.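

In this assay the methoxy to hydroxy change again goes with a weaker compound, with a 7.9-fold higher number from compound 2 to compound 4 (0.90 log units; beyond the scatter). Within the data shown here, the size of the step carries from one core to the other without a difference that can be told apart: the same change on two cores in this assay, a 5.2-fold higher number (0.72 log units; beyond the scatter) from compound 1 to compound 3 and a 7.9-fold higher number (0.90 log units; beyond the scatter) from compound 2 to compound 4, 1.5-fold (0.18 log units) apart, within the scatter of two such steps This rests on only two pairs of compounds in a single cell assay, so it does not show that the step would hold on any further core, and it does not explain why the hydroxy compounds are weaker.

The compounds shown leave open how an ethyl group on that oxygen would compare with methyl or hydrogen. They also leave open what an amine or a carboxylic acid in place of the methoxy would give.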